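Three Piperazine Ketones and a Fourth Awaiting Measurement

The compounds below may be only part of what the source reports. "The series", "measured", "known", "first", "only" and "open" are said of these compounds alone.

In an assay on isolated protein for binding affinity to histamine H2 receptor (Homo sapiens) (a higher number here means a weaker inhibitor, a lower number a stronger inhibitor), the three measured compounds read as follows:

compound 1 `CCCCCC(=O)c1ccc(OCCCN2CCN(S(=O)(=O)c3ccc(C#N)cc3)CC2)cc1` gives 12300 nM
compound 2 `CCCCCC(=O)c1ccc(OCCCN2CCN(C(=O)C(C)(C)O)CC2)cc1` gives 24500 nM
compound 3 `C=C(C)C(=O)c1ccc(OCCCN2CCN(C(=O)OCC)CC2)cc1` gives 22400 nM

All three share the same propoxy-linked piperazine core and differ either at the piperazine nitrogen or at the ketone. For the measured compounds named here, the only step between compounds that differ in one place is the one on the piperazine nitrogen: a 2.0-fold higher number from compound 1 to compound 2 (0.30 log units; within the scatter). Compound 3 stands second highest of the three numbers in this assay; its gap to compound 2 and its gap to compound 1 are both within the scatter, so the three numbers cannot be ordered against one another.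

Compound 4 `CCOC(=O)N1CCN(CCCOc2ccc(C(=O)c3cccc(C)c3)cc2)CC1` is the unmeasured member. It differs from compound 3 at the ketone only: 3-methylphenyl in place of 1-methylethenyl on a carbonyl carbon. Going by the values given here, no measured step touches the ketone side, so the step from compound 1 to compound 2 does not bear on it directly; it only shows that the numbers in this small set move little. With nothing pointing in either direction, the change is expected to produce no step beyond the scatter, so that a 1.1-fold lower number from compound 3 to compound 4 (0.05 log units; within the scatter) is the expected outcome. Compound 4 is therefore estimated at 20000 nM in this assay, with a range from 7000 nM to 60000 nM.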

Compound 4, inhibition constant: 3720 nM
The estimate for compound 4 lay 5.4-fold (0.73 log units) above the measured number; measured number below the stated range.
By their numbers in this assay, from the lowest: compound 4; then compounds 1, 3 and 2 (each within the scatter of the next).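

For the compounds shown here, the ketone side, which the only earlier step did not touch, proves not to be silent in this assay: with the rest of the structure unchanged, putting 3-methylphenyl in place of 1-methylethenyl on a carbonyl carbon gives a 6.0-fold lower number from compound 3 to compound 4 (0.78 log units; beyond the scatter) and so opens a real gap. Of the two steps now available, this is the one beyond the scatter, whereas the change on the amine nitrogen in a ring, a 2.0-fold higher number from compound 1 to compound 2 (0.30 log units; within the scatter), stays within it. The entering group adds an aromatic ring of carbon only and more heavy atoms, with no hydrogen-bond donors or acceptors on either side, but no accompanying measurement speaks to what lies behind the step.

The compounds shown leave open whether the aromatic ring alone carries this step or its methyl also matters, a question that an unsubstituted phenyl on the same carbonyl carbon would address. They also leave open whether a saturated ring such as cyclohexyl would behave like 3-methylphenyl, and whether the step would persist with (4-cyanophenyl)sulfonyl on the amine nitrogen.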